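The source may report more compounds than this note shows. Statements on the series, on what has been measured and on what is new or still open speak of the compounds shown alone.

Compound 2 `COc1ccccc1-n1nc(C2C[C@H](C)O[C@@H](C)C2)cc1-c1ccc(Cl)cc1` stands highest of the two numbers measured in an assay on HEK293 cells for inhibition of Voltage-dependent N-type calcium channel subunit alpha-1B (Homo sapiens), read by patch clamp, using a membrane potential dye (a higher number here means a weaker inhibitor, a lower number a stronger inhibitor), where compound 2 gives 61000 nM. Among the compounds with values here, the only other measured member, compound 1 `COc1ccccc1-n1nc(C2CC(C)(C)OC(C)(C)C2)cc1-c1ccc(Cl)cc1`, gives 16 nM in this assay; the single step measured so far, a 3800-fold higher number from compound 1 to compound 2 (3.58 log units; beyond the scatter), exchanged 2,2,6,6-tetramethyloxan-4-yl for 2,6-dimethyloxan-4-yl on an aromatic carbon. Compound 3 `COc1ccccc1-n1nc([C@@H]2CCO[C@H](C(C)C)C2)cc1-c1ccc(Cl)cc1` differs from compound 2 by 2-isopropyloxan-4-yl in place of 2,6-dimethyloxan-4-yl on an aromatic carbon. Within the data shown here, no measured step covers a change of this kind; the one step recorded shows that altering the substituents on the same oxane ring moved this assay by a very large amount, so a step well beyond the scatter in either direction cannot be excluded for compound 3. Among the measured compounds shown here, compound 3 is expected to land between the two measured members, estimated at 3000 nM with a range from 300 nM to 30000 nM. That estimate means an expected step of a 20-fold lower number from compound 2 to compound 3 (1.31 log units; beyond the scatter).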

Compound 3, half-maximal inhibitory concentration: 55000 nM
The estimate for compound 3 lay 18-fold (1.26 log units) below the measured number, and the stated range ends below it.
By their numbers in this assay, from the lowest: compound 1; then compounds 3 and 2 (each within the scatter of the next).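

In this assay, 2-isopropyloxan-4-yl in place of 2,6-dimethyloxan-4-yl on this aromatic carbon gives a 1.1-fold lower number from compound 2 to compound 3 (0.04 log units; within the scatter), so these two oxane groups cannot be told apart at this position. Set against the 2,2,6,6-tetramethyloxan-4-yl group, the same change gives a 3400-fold higher number from compound 1 to compound 3 (3.54 log units; beyond the scatter), so a second, differently substituted oxane also stands far from compound 1, and among these three compounds only compound 1 carries the low number. No supporting data bear on what separates compound 1 from the other two.

Still open, on these data alone, is whether 2,2-dimethyloxan-4-yl, with one side of the tetramethyl pattern removed, would stay close to compound 1 or fall with compound 2 and compound 3. Also open, as far as these compounds go, is how an amine or a hydroxyl on the oxane ring would read at this position.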